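The source may report more compounds than this note shows. Statements on the series, on what has been measured and on what is new or still open speak of the compounds shown alone.

Compound 1 `CC(=O)N1N=C(c2ccc3ccccc3c2)OC1c1cccc(F)c1` and compound 2 `CC(=O)N1N=C(c2ccc3ccccc3c2)OC1c1ccc2ccccc2c1` share the same core and differ only in one ring. Among the measured compounds shown here, in a functional assay on B16-F10 cells (Mus musculus) for antiproliferative activity, read by MTT assay, with a stated time of 48 h (on this read-out lower numbers stand for stronger inhibition and higher numbers for weaker inhibition), compound 1 gives 1.61 ug/mL and compound 2 gives 1.56 ug/mL; of these two numbers the one for compound 1 is the larger, yet the gap lies within the usual scatter, so the two cannot be told apart. Compound 3 `CC(=O)N1N=C(c2ccc3ccccc3c2)OC1c1ccsc1` has not yet been tested. It differs from compound 1 by thiophen-3-yl in place of 3-fluorophenyl on a saturated ring carbon. For the measured compounds named here, with no measured step of this kind to lean on, only a small change is expected, in no fixed direction, and the step of a 1.2-fold higher number from compound 1 to compound 3 (0.09 log units; within the scatter) is expected to stay within the scatter. Compound 3 is therefore estimated at 2 ug/mL, between 1 ug/mL and 4 ug/mL.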

Compound 3, half-maximal inhibitory concentration: 8.56 ug/mL
Compound 3: middle estimate off by 4.3-fold (0.63 log units), on the low side, and the stated range ends below it.
By their numbers in this assay, from the lowest: compounds 2 and 1 (each within the scatter of the next); then compound 3.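

In this assay, the group on this saturated ring carbon is not freely interchangeable: thiophen-3-yl in place of 3-fluorophenyl gives a 5.3-fold higher number from compound 1 to compound 3 (0.73 log units; beyond the scatter). The earlier pair gave no sign of this, since compound 1 at 1.61 ug/mL and compound 2 at 1.56 ug/mL lie within the scatter of each other despite carrying different rings here. Among the compounds shown here, nothing measured so far explains the step. The compounds shown leave open whether a plain phenyl, a furan-3-yl or a pyridin-3-yl at this carbon would stay close to compound 1 or to compound 3.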